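The source may report more compounds than this note shows. Statements on the series, on what has been measured and on what is new or still open speak of the compounds shown alone.

Three related compounds have been tested in a functional assay on L1210 cells (Mus musculus) for antiproliferative activity, read by cell counting, with a stated time of 48 h; on this read-out higher numbers stand for weaker inhibition and lower numbers for stronger inhibition. Compound 1 `C#C[C@@]1(O)[C@@H](CO)O[C@@H](n2cnc3c(-c4ccc(OC)cc4)ncnc32)[C@@H]1O` gave only a limit, > 250000 nM. Compound 3 `C#C[C@@]1(O)[C@@H](CO)O[C@@H](n2c(C(F)(F)F)cc3c(N)ncnc32)[C@@H]1O` likewise gave only a limit, > 250000 nM. Compound 2 `C#C[C@@]1(O)[C@@H](CO)O[C@@H](n2cc(Br)c3c(N)ncnc32)[C@@H]1O` alone gave an actual number, 28 nM. Within the data shown here, the series so far therefore consists of the limit of > 250000 nM in this assay, at which 2 of the 3 values shown sit, plus that one measured value, with no second number to compare it against.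

Compound 4 `C#Cc1cn([C@@H]2O[C@H](CO)[C@](O)(C#C)[C@H]2O)c2ncnc(N)c12` has yet to be measured. It differs from compound 2 at a single place, with ethynyl in place of bromo on an aromatic carbon. Among the measured compounds shown here, no pair of measured compounds isolates this change, so the only anchor for a prediction is compound 2 at 28 nM. For the measured compounds named here, the two limits offer no measured step to scale it by. In this assay a modest move toward weaker inhibition is expected, although it may not reach far beyond the usual scatter, and the estimated change is a 2.1-fold higher number from compound 2 to compound 4 (0.33 log units; beyond the scatter). For compound 4 the estimated value is 60 nM, with an expected range of 12 nM to 400 nM.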

Compound 4, half-maximal inhibitory concentration: 159000 nM
Estimate against measurement, compound 4: 2700-fold (3.42 log units) below; measured number above the stated range.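

In this assay, the exchange of bromo for ethynyl on this aromatic carbon of the five-membered ring gives a 5700-fold higher number from compound 2 to compound 4 (3.75 log units; beyond the scatter), which shows that this position is far from indifferent to the group it carries. The earlier compounds shown here gave one number and no step, so they could not show how much of the inhibition of compound 2 depended on this group. Here a small exchange, with no ring added, no net charge and neither group counting any hydrogen-bond donor or acceptor, is enough to carry compound 4 toward the top of the values seen in the series, where the limit of the read-out lies: the limit of > 250000 nM in this assay, at which 2 of the 4 values shown sit.

This single step cannot say whether bromo is unusually favourable here or ethynyl unusually poor, and a chloro, methyl or nitrile group on the same carbon would help separate the two readings. Compounds 1 and 3 add nothing to this comparison, since they gave only limits and their steps to the others cannot be read.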